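Extending Methylamino to Ethylamino on a Shared Core

The compounds below may be only part of what the source reports. "The series", "measured", "known", "first", "only" and "open" are said of these compounds alone.

Three compounds sharing one core were measured in an assay on isolated protein (strain Sprague-Dawley) for inhibition of Amine oxidase [flavin-containing] B (Rattus norvegicus), read by spectrophotometry, with a stated time of 5 min; a lower number here means a stronger inhibitor, a higher number a weaker inhibitor. Compound 1 `CN(C)C(=O)COc1cc(=O)oc2cc(OCc3cccc(Cl)c3)ccc12` gives 501 nM, compound 2 `O=c1cc(Oc2ccccc2)c2ccc(OCc3cccc(Cl)c3)cc2o1` gives 4070 nM, and compound 3 `CNc1cc(=O)oc2cc(OCc3cccc(Cl)c3)ccc12` gives 8.71 nM. Compound 3 therefore stands lowest of the three, with the nearest number coming from compound 1 and the furthest from compound 2.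

Compound 4 `CCNc1cc(=O)oc2cc(OCc3cccc(Cl)c3)ccc12` differs from compound 3 in one place: methyl in place of hydrogen on a saturated chain carbon bound to a nitrogen on an aromatic ring. Going by the values given here, no measured step repeats this exact change. The steps that come closest are a 58-fold lower number from compound 1 to compound 3 (1.76 log units; beyond the scatter) and a 470-fold lower number from compound 2 to compound 3 (2.67 log units; beyond the scatter), both of which replace a far larger group at that aromatic carbon with methylamino, and an 8.1-fold higher number from compound 1 to compound 2 (0.91 log units; beyond the scatter), which swaps one of those larger groups for the other. Those steps say that what sits on this carbon matters a great deal, but they show the effect of exchanging whole groups, not of adding a single carbon to the methylamino chain. A single added carbon is a much smaller change than any of these, so in this assay the expected step of a 1.7-fold higher number from compound 3 to compound 4 (0.24 log units; within the scatter) is small, at most a modest rise, and may fall within the scatter.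

Compound 4 is therefore expected to give about 15 nM, within a range of 5 nM to 60 nM.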

Compound 4, half-maximal inhibitory concentration: 28.2 nM
Beside the measured number, compound 4's estimate is 1.9-fold (0.27 log units) below it, and the stated range covers the measured number.
By their numbers in this assay, from the lowest: compound 3; then compound 4; then compound 1; then compound 2.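

In this assay, the single added carbon has a visible effect (a 3.2-fold higher number from compound 3 to compound 4 (0.51 log units; beyond the scatter)). This shows that the chain on the nitrogen is sensitive to even one methyl, something the earlier exchanges of whole groups could not reveal. Ethylamino still keeps most of the lead that methylamino holds over the two larger groups, both against phenoxy (a 140-fold lower number from compound 2 to compound 4 (2.16 log units; beyond the scatter)) and against (dimethylcarbamoyl)methoxy (an 18-fold lower number from compound 1 to compound 4 (1.25 log units; beyond the scatter)), so growing the chain by this much costs far less than replacing the amino group altogether. Nothing available here accounts for the rise from methylamino to ethylamino.

Methylamino and ethylamino give only one step along the chain, so it remains open whether the number would keep rising with a longer chain such as propylamino, or with a branched one such as isopropylamino. Also open, as far as these compounds go, is how the plain amino group, with two hydrogens on the nitrogen, or dimethylamino, with no hydrogen left there, would compare with methylamino on the shared core.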